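A small change on a carbonyl carbon

This account rests on a few compounds, and the source may have more. Where it says the series, first, only, none or still open, it means among the compounds named here.

Values in a functional assay on MV4-11 cells (Homo sapiens) for antiproliferative activity, read by luminescence, with a stated time of 72 h; a lower number here means a stronger inhibitor, a higher number a weaker inhibitor:
Compound 1 `C=CS(=O)(=O)NC/C=C/c1cc(OC)cc(O)c1C(=O)OCc1ccc(Br)cc1`: 6060 nM
Compound 2 `COc1cc(O)c(C(=O)OC(C)C)c(/C=C/CNC(C)=O)c1`: > 10000 nM, a limit and not a number
Compound 3 `C=CS(=O)(=O)NC/C=C/c1cc(OC)cc(O)c1C(=O)OCC(C)c1ccccc1`: 7730 nM

Compound 2 has no exact value, and its place on the scale is the limit of > 10000 nM in this assay, at which 1 of the 3 values shown sits. Any comparison with it therefore starts from a limit.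

Compound 4 `C/C=C/C(=O)NC/C=C/c1cc(OC)cc(O)c1C(=O)OC(C)C` has prop-1-en-1-yl in place of methyl on a carbonyl carbon, and the rest of compound 2 stays the same. The change is prop-1-en-1-yl in place of methyl on a carbonyl carbon.

Within the data shown here, only one measured step is available, and it offers weak guidance. It is a 1.3-fold higher number from compound 1 to compound 3 (0.11 log units; within the scatter), so it lies within the scatter. Among the measured compounds shown here, that step replaces a different group, and no measured pair shows a change at this carbonyl carbon. The size of the new step in this assay therefore has no direct measurement behind it, and no shift beyond the scatter is expected in either direction.

The expected step is a step that the limit leaves unreadable from compound 2 to compound 4. A reported limit is also quite likely for this compound. For compound 4 the estimated value is 12000 nM, with an expected range of 6000 nM to 24000 nM.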

Compound 4, half-maximal inhibitory concentration: > 10000 nM
Compound 4 ended at the assay's limit; the forecaster's own chance of this, stated with the estimate: 65%; the middle value does not contradict the limit.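

In this assay compound 4 gives > 10000 nM as a limit and not a number. Among these compounds, compound 2 also stands at a limit, so no step between compound 2 and compound 4 can be read: the limit of > 10000 nM in this assay, at which 2 of the 4 values shown sit. The compounds shown leave open whether prop-1-en-1-yl in place of methyl on a carbonyl carbon moves the number in either direction, and by how much.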